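The compounds below may be only part of what the source reports. "The series", "measured", "known", "first", "only" and "open" are said of these compounds alone.

Compound 2 `C[C@H](NC(=O)c1c(Cc2cccc(Cl)c2)sc2c1CCOC2)c1ccc(C(=O)O)cc1` is the starting point. In a functional assay on CHO/Galpha16 cells for antagonist activity at prostaglandin E2 receptor EP4 subtype (Homo sapiens), read by calcium flux, with a stated time of 15 min (on this read-out higher numbers stand for weaker inhibition and lower numbers for stronger inhibition), compound 2 gives 3.2 nM, the lowest of the three numbers measured. Compound 3 `C[C@H](NC(=O)c1c(Cc2ccc(OC(F)(F)F)c(Cl)c2)sc2c1CCOC2)c1ccc(C(=O)O)cc1` gives 6.6 nM, which is a 2.1-fold higher number from compound 2 to compound 3 (0.31 log units; beyond the scatter). Compound 1 `COc1cccc(C#Cc2sc3c(c2C(=O)N[C@@H](C)c2ccc(C(=O)O)cc2)CCOC3)c1` gives 12.4 nM. Exchanging 2-(3-methoxyphenyl)ethynyl for 3-chlorobenzyl went with a 3.9-fold lower number from compound 1 to compound 2 (0.59 log units; beyond the scatter). Compound 4 `C[C@H](NC(=O)c1c(C#Cc2ccc(F)cc2)sc2c1CCOC2)c1ccc(C(=O)O)cc1` differs from compound 2 in one place: 2-(4-fluorophenyl)ethynyl in place of 3-chlorobenzyl on an aromatic carbon. This is nearly the reverse of the change seen between compound 1 and compound 2, with 2-(4-fluorophenyl)ethynyl instead of 2-(3-methoxyphenyl)ethynyl entering, so a modest upward step is expected, a 2.8-fold higher number from compound 2 to compound 4 (0.45 log units; beyond the scatter). Compound 4 is therefore estimated at 9 nM, with a likely range from 4 nM to 25 nM.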

Compound 4, half-maximal inhibitory concentration: 15.8 nM
Beside the measured number, compound 4's estimate is 1.8-fold (0.24 log units) below it; the measured number falls inside the stated range.
By their numbers in this assay, from the lowest: compound 2; then compounds 3, 1 and 4 (each within the scatter of the next, the first and the last beyond it).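

On this aromatic carbon next to the ring sulfur, a second aryl-bearing triple bond also gives a weaker result than the 3-chlorobenzyl of compound 2, with a 4.9-fold higher number from compound 2 to compound 4 (0.69 log units; beyond the scatter) in this assay. Within the triple-bonded series, the swap to 4-fluorophenyl leaves the result within the scatter, with a 1.3-fold higher number from compound 1 to compound 4 (0.11 log units; within the scatter) here, so these two aryl ends cannot be told apart. What an amine or a longer alkyl chain would give at this position stays open, and no available evidence accounts for either step.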